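The source may hold more compounds than are shown below. What is called first, only, known or untested is meant among the compounds shown, and "the series" means these compounds.

Measured compounds:
compound 1 `CC(=O)Oc1ccccc1C(=O)OCC[Se]C#N` — in a functional assay on HT-29 cells (Homo sapiens) for antiproliferative activity, read by MTT assay, with a stated time of 24 h (a lower number here means a stronger inhibitor, a higher number a weaker inhibitor), compound 1 gives 10200 nM
compound 2 `CC(=O)Oc1ccccc1C(=O)[Se]CC[Se]C(=O)c1ccccc1OC(C)=O` — compound 2 gives 18600 nM
compound 3 `C[Se]CC(NC(=O)c1ccccc1OC(C)=O)C(=O)O` — compound 3 reaches only the limit > 50000 nM

The value of compound 3 is a limit of this assay, not a number (the limit of > 50000 nM in this assay, at which 1 of the 3 values shown sits). Of the two numbers that remain, compound 1 and compound 2 lie within the usual scatter of each other, so they cannot be told apart on the data shown. Going by the values given here, there is no measured step between compounds that differ in one place, so nothing here calibrates the size of a single change.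

Compound 4 `CC(=O)Oc1ccccc1C(=O)NCCSC#N` is not yet measured. It differs from compound 1 in one place: a group of 6 heavy atoms (3 carbon, 2 nitrogen, 1 sulfur; no ring) in place of a group of 6 heavy atoms (3 carbon, 1 nitrogen, 1 oxygen, 1 selenium; no ring), on a carbonyl carbon. From the compounds shown here alone, whether this change shifts the number is unknown from these compounds; the expectation is a shift no larger than the scatter, with the weaker side somewhat more likely given how little the other members of the set achieve. Compound 4 is therefore expected at about 18000 nM, with a range from 6000 nM to 50000 nM. That estimate corresponds to an expected step of a 1.8-fold higher number from compound 1 to compound 4 (0.25 log units; within the scatter).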

Compound 4, half-maximal inhibitory concentration: > 50000 nM
Compound 4: no number, only a limit; the forecaster's own chance of this, stated with the estimate: 30%; middle value at least 2.7-fold (0.44 log units) from the limit.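

Exchanging the group on the carbonyl carbon for (2-(cyanosulfanyl)ethyl)amino gives, in this assay, an at least 4.9-fold higher number from compound 1 to compound 4 (0.69 log units; beyond the scatter). Going by these compounds alone, this is the first step in the set between compounds that differ in one place, and it shows that the group at this carbonyl carbon is not interchangeable, even though the entering and leaving groups have the same heavy-atom count. Compound 4 gives a limit of the assay, not a number, so the full size of the step stays unknown: the limit of > 50000 nM in this assay, at which 2 of the 4 values shown sit.

The change puts nitrogen in place of oxygen and sulfur in place of selenium at once, and the compounds shown cannot say which exchange accounts for the step. An amide carrying the selenium-bearing chain, or an ester carrying the sulfur-bearing chain, would separate the two.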